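Methoxy for ethyl on the naphthalene-type core: note on compound 3

The source may hold more compounds than are shown below. What is called first, only, known or untested is meant among the compounds shown, and "the series" means these compounds.

Two compounds of this series carry numbers in a functional assay on MCF7 cells (Homo sapiens) for cytotoxicity, read by sulforhodamine B assay, with a stated time of 72 h; a lower number here means that less compound is needed, a higher number that more compound is needed for the effect. Compound 1, `CCc1cccc2c(OC)c(-c3occ(C)c3C(=O)OC)ccc12`, gives 2.5 ug/mL in this assay. Compound 2, `CCc1cccc2c(O)c(-c3occ(C)c3C(=O)O)ccc12`, gives 3.3 ug/mL in this assay; its number and that of compound 1 lie within the usual scatter of each other, so the two stand together rather than apart. Compound 3, `COc1cccc2c(O)c(-c3occ(C)c3C(=O)O)ccc12`, has not yet been measured. Against compound 2 it differs in one place: methoxy in place of ethyl on an aromatic carbon. For the measured compounds named here, no step between two measured compounds describes this change, and the two compounds in hand differ in other places, so nothing in the data fixes its size or direction. Compound 2 is the only anchor. The expected step, a 1.2-fold higher number from compound 2 to compound 3 (0.06 log units; within the scatter), is therefore none beyond the scatter, with a slight lean toward a higher number. Compound 3 is estimated at 3.8 ug/mL, with a range from 1.6 ug/mL to 9 ug/mL.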

Compound 3, concentration for half-maximal effect: > 20 ug/mL
Compound 3: a limit, no number; the forecaster's own chance of this, stated with the estimate: 5%; middle value at least 5.2-fold (0.72 log units) from the limit.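

In this assay, for the compounds shown here, methoxy in place of ethyl on this aromatic carbon gives the first readable single change: an at least 6.0-fold higher number from compound 2 to compound 3 (0.78 log units; beyond the scatter). Compound 3 stands at a limit of the assay, not at a number: the limit of > 20 ug/mL in this assay, at which 1 of the 3 values shown sits. Ethyl and methoxy carry the same count of heavy atoms, so at this position that count alone does not preserve the result, and the change also brings in a hydrogen-bond acceptor, although the data do not tie the step to that acceptor.

On these data alone, how far compound 3 lies past its limit remains open, as does whether the same change would have a similar effect on the core of compound 1. An amine or a longer chain such as propyl at this position would help show whether the step follows the oxygen of methoxy or the loss of ethyl.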